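The source may report more compounds than this note shows. Statements on the series, on what has been measured and on what is new or still open speak of the compounds shown alone.

Measured in a functional assay on the whole organism (blood) with Rattus norvegicus as the target, with stated times of 24 h and 1 h, at a dose of 5 mg/kg by the intraperitoneal route; a higher number here means a stronger effect of the compound at the dose given, a lower number a weaker effect:
compound 1 `COc1ccc(Cl)cc1C(=O)NCCC1CCN(S(=O)(=O)NC(=O)NC2CCCCC2)CC1`: 25%
compound 2 `COc1ccc(Cl)cc1C(=O)NCCC1CCN(S(=O)(=O)NC(=O)NC[C@@H]2C[C@@H]3CC[C@@H]2O3)CC1`: 30%
compound 3 `COc1ccc(Cl)cc1C(=O)NCCC1CCN(S(=O)(=O)NC(=O)NC[C@H]2C[C@@H]3CC[C@@H]2O3)CC1`: 27%

Compound 1 gives the smallest of the three numbers in this assay, although the steps of a number 2 percentage points higher from compound 1 to compound 3 (within the scatter) and a number 5 percentage points higher from compound 1 to compound 2 (within the scatter) both stay within the scatter, as does a number 3 percentage points lower from compound 2 to compound 3 (within the scatter) for the pair that differs only in configuration (the fact that compounds 2 and 3 differ only in the configuration as drawn). All three measured steps change the group on an amide-type nitrogen and leave the rest of the shared core untouched.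

Compound 4 `O=C(NC1CCCCC1)NS(=O)(=O)N1CCC(CCNC(=O)c2ccc3ccccc3n2)CC1` alters a different part of compound 1: quinolin-2-yl in place of 5-chloro-2-methoxyphenyl on a carbonyl carbon. Among the measured compounds shown here, no measured step touches this carbonyl-carbon position, so the three measured steps give no guide beyond showing that the series so far moves only within the scatter. Compound 4 is therefore expected to sit near compound 1, with no change at the digits printed from compound 1 to compound 4 (within the scatter) taken as no step beyond the scatter; the estimate for compound 4 is 25%, in the range 8% to 42%.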

Compound 4, a percentage reported as activity, at one dose (the size of the read-out at that dose, not a potency): 11%
The estimate for compound 4 lay 14 percentage points above the measured number; measured number inside the range.
By their numbers in this assay, from the lowest: compound 4; then compounds 1, 3 and 2 (each within the scatter of the next).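

At the carbonyl carbon, this assay does respond: quinolin-2-yl in place of 5-chloro-2-methoxyphenyl gives a number 14 percentage points lower from compound 1 to compound 4 (beyond the scatter). Among the compounds shown here, this is the first step to pass the scatter, as the earlier steps, all on an amide-type nitrogen, did not. No measured property available here bears on this drop.

Open, going by these compounds, is how an unsubstituted phenyl or a pyridin-2-yl group would read on this carbonyl carbon, which would help separate the part played by the departing chlorine and methoxy from that of the entering fused ring. Also open, on these data alone, is whether the drop carries over to compounds with a different group on the amide-type nitrogen.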